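Phenyl for ethyl on the pyridyl ether: expected effect

The source may report more compounds than this note shows. Statements on the series, on what has been measured and on what is new or still open speak of the compounds shown alone.

Measured so far:
compound 1 `C[C@@H]1CC[C@@H](Oc2cc(C#N)ccn2)CN1C(=O)c1ccccc1CC(F)(F)F` — > 10000 nM
compound 2 `CCc1ccnc(O[C@@H]2CC[C@@H](C)N(C(=O)c3ccccc3-n3nccn3)C2)c1` — 310 nM

For the measured compounds named here, in a functional assay on CHO-K1 cells for antagonist activity at Orexin/Hypocretin receptor type 1 (Homo sapiens), read by FLIPR and calcium flux (on this read-out higher numbers stand for weaker inhibition and lower numbers for stronger inhibition), compound 2 gives 310 nM, the only numerical value recorded for this pair. For compound 1 the entry of > 10000 nM is a limit of this assay and not a number; (the limit of > 10000 nM in this assay, at which 1 of the 2 values shown sits). Going by the values given here, no step between compounds that differ in one place is available, so the starting point is compound 2 alone.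

Compound 3 `C[C@@H]1CC[C@@H](Oc2cc(-c3ccccc3)ccn2)CN1C(=O)c1ccccc1-n1nccn1` is not yet measured. It differs from compound 2 by phenyl in place of ethyl on an aromatic carbon of the six-membered aromatic ring with one nitrogen, meta to a large group and opposite the ring nitrogen. Compounds 1 and 2 differ at two positions, so they give no guidance on this change by itself.

A moderate gain in potency is expected for compound 3, of size a 2.1-fold lower number from compound 2 to compound 3 (0.32 log units; beyond the scatter), though a step no larger than the usual scatter is also plausible. The estimate for compound 3 in this assay is 150 nM, ranging from 40 nM to 600 nM.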

Compound 3, half-maximal inhibitory concentration: 2400 nM
Compound 3: the middle estimate sits 16-fold (1.20 log units) below what was measured; measured number above the stated range.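

Phenyl in place of ethyl on an aromatic carbon, meta to a large group and opposite the ring nitrogen, gives the first single-place reading in the series: in this assay there is a 7.7-fold higher number from compound 2 to compound 3 (0.89 log units; beyond the scatter), a step that is beyond the scatter and points to weaker inhibition. This carbon is therefore not indifferent to the group it carries, and here the larger, ring-bearing group is the less favourable of the two, although compound 3 still gives a numerical value rather than a limit of the assay. Nothing available here explains why the step runs in this direction.

Going by these compounds, a single step cannot separate the effect of the aromatic ring from that of the added heavy atoms, so it remains open how methyl, cyclopropyl, cyclohexyl or a pyridyl ring would read at this carbon, and whether the response follows group size or the presence of an aromatic ring. For the compounds shown here, it is also open whether the same step would hold with an amide part other than the one shared by compound 2 and compound 3.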